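Trifluorophenyl in place of difluorophenyl at the assay limit

This account rests on a few compounds, and the source may have more. Where it says the series, first, only, none or still open, it means among the compounds named here.

Results so far in a functional assay on G-361 cells (Homo sapiens) for antiproliferative activity, with a stated time of 72 h (on this read-out lower numbers stand for stronger inhibition and higher numbers for weaker inhibition), for the three measured compounds

Compound 1 `OC[C@H]1O[C@@H](n2cnc3c(NCc4ccccc4Cl)ncnc32)[C@H](O)[C@@H]1O` has the entry "not determined" (no result reported) in place of a result
Compound 2 `OC[C@H]1O[C@@H](n2cnc3c(NCc4cccc(Br)c4)ncnc32)[C@H](O)[C@@H]1O` gives > 166000 nM as a limit
Compound 3 `OC[C@H]1O[C@@H](n2cnc3c(NCc4ccc(F)cc4F)ncnc32)[C@H](O)[C@@H]1O` gives > 166000 nM as a limit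

Compound 3 has no number in this assay and stands only at a limit (> 166000 nM). Compound 2 is also reported only as a limit (> 166000 nM). The picture is thus (the limit of > 166000 nM in this assay, at which 2 of the 3 values shown sit), and compound 1 adds no result.

Compound 4 `OC[C@H]1O[C@@H](n2cnc3c(NCc4c(F)ccc(F)c4F)ncnc32)[C@H](O)[C@@H]1O` differs from compound 3 in one place: 2,3,6-trifluorophenyl in place of 2,4-difluorophenyl on a saturated chain carbon bound to a nitrogen on an aromatic ring. In words, it carries 2,3,6-trifluorophenyl in place of 2,4-difluorophenyl on a saturated chain carbon bound to a nitrogen on an aromatic ring.

For the measured compounds named here, only one measured step bears on this change. It is a step that the two limits leave unreadable from compound 2 to compound 3, a swap at the same place, and it offers no size to carry over. Going by the values given here, no step of definite size or direction can therefore be expected in this assay, and the most likely outcome is another limit. The expected step is an at least 1.1-fold lower number from compound 3 to compound 4 (0.04 log units; that floor lies within the scatter), and it should be read loosely. For compound 4 the estimate is 150000 nM, with an expected range from 30000 nM to 250000 nM in this assay.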

Compound 4, half-maximal inhibitory concentration: > 166000 nM
Compound 4 ended at the assay's limit; the forecaster's own chance of this, stated with the estimate: 70%; middle value at least 1.1-fold (0.04 log units) from the limit.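

Compound 4 is reported only as a limit in this assay, as are compound 2 and compound 3, so no step among these three compounds can be read: the limit of > 166000 nM in this assay, at which 3 of the 4 values shown sit.

The compounds shown leave open whether the bromophenyl, difluorophenyl and trifluorophenyl groups differ at all in this assay, and whether any phenyl group at this place would give a measurable value.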